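A sulfobenzyl ether at the chain end of compound 3

This account rests on a few compounds, and the source may have more. Where it says the series, first, only, none or still open, it means among the compounds named here.

Compound 3 `COC1=C(OC)C(=O)C(CCCCCCCCCCOc2cc(O)cc(O)c2)=C(C)C1=O` ends its chain in a 3,5-dihydroxyphenoxy group. In a functional assay on HL-60 cells (Homo sapiens) for antiproliferative activity, read by MTT assay, with a stated time of 48 h (on this read-out higher numbers stand for weaker inhibition and lower numbers for stronger inhibition), compound 3 gives 16000 nM, the highest of the two numbers recorded here. Compound 2 `COC1=C(OC)C(=O)C(CCCCCCCCCCn2ccnc2)=C(C)C1=O` gives 3000 nM in this assay, and a 5.3-fold higher number from compound 2 to compound 3 (0.73 log units; beyond the scatter). Compound 1 `COC1=C(OC)C(=O)C(CCCCCCCCCCOc2c(O)cc(O)cc2O)=C(C)C1=O` reaches only a limit of this assay, namely > 200000 nM. Among the compounds with values here, the step of an at least 12-fold lower number from compound 1 to compound 3 (1.09 log units; beyond the scatter) is the one change made at the same oxygen. Compound 4 `COC1=C(OC)C(=O)C(CCCCCCCCCCOCc2cccc(S(=O)(=O)O)c2)=C(C)C1=O` differs from compound 3 in that (3-sulfobenzyl in place of 3,5-dihydroxyphenyl on an oxygen on a saturated carbon). Neither measured step involved a sulfonic acid, so the guidance is weak; the change is expected to amount to a 1.9-fold higher number from compound 3 to compound 4 (0.27 log units; within the scatter), toward weaker inhibition. Compound 4 is therefore expected to give 30000 nM in this assay, between 8000 nM and 150000 nM.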

Compound 4, half-maximal inhibitory concentration: 143000 nM
For compound 4 the middle estimate is 4.8-fold (0.68 log units) below the measured one; low and high end bracket the measured number.
By their numbers in this assay, from the lowest: compound 2; then compound 3; then compound 4. At a limit, above all of these: compound 1.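

In this assay putting 3-sulfobenzyl in place of 3,5-dihydroxyphenyl on this oxygen weakens inhibition and gives an 8.9-fold higher number from compound 3 to compound 4 (0.95 log units; beyond the scatter) as the step. This shows that a sulfonic acid-bearing benzyl ether at the chain end, unlike the groups compared earlier, places the compound close to the top of the measured range, well above compound 2 and compound 3. Against the limit of compound 1 the change gives only an at least 1.3-fold lower number from compound 1 to compound 4 (0.14 log units; that floor lies within the scatter) as a floor, so no order can be read from it. Compound 1 remains a limit: the limit of > 200000 nM in this assay, at which 1 of the 4 values shown sits.

From the compounds shown here alone, whether the loss follows the sulfonic acid or the benzyl carbon remains open. A plain benzyl ether or a 3-carboxybenzyl group on this oxygen would separate the two.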